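Phenyl to Furan-2-yl: a Small Ring Swap Tested

The source may hold more compounds than are shown below. What is called first, only, known or untested is meant among the compounds shown, and "the series" means these compounds.

Compound 2 `Cc1nc(O)c2cc(CS/C(S)=N/Cc3ccccc3)ccc2n1` is the stronger of two measured compounds in a functional assay on K562 cells (Homo sapiens) for cytotoxicity; a lower number here means a stronger inhibitor, a higher number a weaker inhibitor: compound 2 gives 4000 nM, while compound 1 `Cc1nc(O)c2cc(CS/C(S)=N/CCCN(C)C)ccc2n1` gives 25600 nM. Among the compounds with values here, the only measured step, a 6.4-fold lower number from compound 1 to compound 2 (0.81 log units; beyond the scatter), traded a flexible amine chain for an aromatic ring. Compound 3 `Cc1nc(O)c2cc(CS/C(S)=N/Cc3ccco3)ccc2n1` differs from compound 2 by furan-2-yl in place of phenyl on a saturated chain carbon bound to a double-bonded nitrogen, so benzyl becomes (furan-2-yl)methyl, one aromatic ring for another. Within the data shown here, no measured pair tests such a ring swap. Compound 3 is therefore expected to change little, a 1.3-fold higher number from compound 2 to compound 3 (0.10 log units; within the scatter), staying within the scatter. The estimate for compound 3 is 5000 nM, with a range from 1500 nM to 16000 nM.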

Compound 3, half-maximal inhibitory concentration: 2100 nM
Compound 3: middle estimate off by 2.4-fold (0.38 log units), on the high side; the measured number falls inside the stated range.
By their numbers in this assay, from the lowest: compounds 3 and 2 (each within the scatter of the next); then compound 1.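

In this assay the ring swap reads as a 1.9-fold lower number from compound 2 to compound 3 (0.28 log units; within the scatter), so at this place, on a saturated chain carbon bound to a double-bonded nitrogen, furan-2-yl and phenyl cannot be told apart. The step of a 12-fold lower number from compound 1 to compound 3 (1.09 log units; beyond the scatter) shows that a second aromatic ring also gives a lower number than the 2-(dimethylamino)ethyl group. Nothing measured here speaks to the reason for these numbers. As far as these compounds go, whether a thiophene ring or a saturated cyclohexyl ring would match these two remains open. So does the effect of a longer chain between the ring and the nitrogen.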